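The source may hold more compounds than are shown below. What is called first, only, known or untested is meant among the compounds shown, and "the series" means these compounds.

Compound 1, whose structure is `COc1ccc2[nH]c3c(c4c(c5ccnn53)C(=O)NC4=O)c2c1`, was tested in a functional assay on OE21 cells (Homo sapiens) for cytotoxicity, read by MTT assay, with a stated time of 72 h (on this read-out higher numbers stand for weaker inhibition and lower numbers for stronger inhibition), where compound 1 gives 35000 nM. Compound 2, with structure `Cc1ccc2[nH]c3c(c4c(c5ccnn53)C(=O)NC4=O)c2c1`, carries the change methyl in place of methoxy on an aromatic carbon relative to compound 1, and in this assay compound 2 gives 5000 nM. The step is a 7.0-fold lower number from compound 1 to compound 2 (0.85 log units; beyond the scatter).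

Compound 3, with structure `COc1ccc2[nH]c(-n3cccn3)cc2c1`, rests on a different core; the difference between the two cores is not broken down here. In this assay compound 3 is reported only as a limit, > 100000 nM, as noted in the limit of > 100000 nM in this assay, at which 1 of the 3 values shown sits.

Compound 4, with structure `Cc1ccc2[nH]c(-n3cccn3)cc2c1`, is derived from compound 3 by methyl in place of methoxy on an aromatic carbon. Within the data shown here, this is the same kind of change as the one from compound 1 to compound 2, but not the same: in compound 1 the ring bearing the group is part of a fused or bridged system of five rings, while in compound 3 it is part of a fused or bridged system of two rings. Since compound 3 sits at a limit, the earlier step can only suggest a direction, and the estimated step is a number no higher from compound 3 to compound 4 (the limit leaves the size open). Compound 4 is therefore expected to give about 100000 nM, within roughly 30000 nM to 300000 nM.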

Compound 4, half-maximal inhibitory concentration: > 100000 nM
Compound 4 ended at the assay's limit (the forecaster's own chance of this, stated with the estimate: 65%); the middle value lies on the limit itself.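

Compound 3 and compound 4 both stand at a limit in this assay rather than at a number, so no step between them can be read: the limit of > 100000 nM in this assay, at which 2 of the 4 values shown sit.

The compounds shown leave open whether methyl in place of methoxy on an aromatic carbon shifts the read-out on the core of compound 3 as it does on the core of compound 1.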